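Anilide swap from compound 3 to compound 4

This account rests on a few compounds, and the source may have more. Where it says the series, first, only, none or still open, it means among the compounds named here.

Three compounds of this series carry a measurement in a functional assay on the whole organism (strain Swiss albino) for inhibition, with Mus musculus as the target, in the formalin test, with a stated time of 30 min, at a dose of 100 mg/kg; on this read-out higher numbers stand for more inhibition at the one dose given (going by the name of the read-out) and lower numbers for less inhibition. Compound 1 `CCN1CCc2c(c(C)nn2C(=O)Nc2cc(C)ccc2C)C1` gives 55.8%. Compound 2 `CCN1CCc2c(c(C(C)(C)C)nn2C(=O)Nc2ccc(Br)cc2)C1` gives 72.1%. Compound 3 `CCN1CCc2c(c(C(C)(C)C)nn2C(=O)Nc2c(C)cccc2C)C1` gives 68%, the second highest of the three numbers; the nearest is compound 2, whose gap to compound 3 lies within the scatter, while compound 1 lies farther off, beyond the scatter.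

Compound 4 `CCN1CCc2c(c(C(C)(C)C)nn2C(=O)Nc2cc(C)ccc2C)C1` has not been measured. It differs from compound 3 in one place: 2,5-dimethylphenyl in place of 2,6-dimethylphenyl on an amide-type nitrogen.

Among the compounds with values here, the one measured step that alters only the group on the amide-type nitrogen is a number 4.1 percentage points lower from compound 2 to compound 3 (within the scatter). Within the data shown here, compound 1 also carries a 2,5-dimethylphenyl on that nitrogen but has methyl in place of tert-butyl, so no single-change step joins it to compound 3 or to compound 4; its value and that of compound 3 simply show a gap beyond the scatter. On this footing the change to compound 4 is expected to move the read-out in this assay little, and a step of a number 4 percentage points lower from compound 3 to compound 4 (within the scatter) is the working estimate. Compound 4 is therefore expected to give about 64% in this assay, with a range from 50% to 78%.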

Compound 4, a percentage reported as inhibition, in the whole organism at one dose (the size of the read-out at that dose, not a potency): 15.7%
Beside the measured number, compound 4's estimate is 48.3 percentage points above it, outside the stated range (below it).
By their numbers in this assay, from the lowest: compound 4; then compound 1; then compounds 3 and 2 (each within the scatter of the next).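

In this assay the group on the amide-type nitrogen proves far more sensitive than the earlier step (a number 4.1 percentage points lower from compound 2 to compound 3 (within the scatter)) suggested: 2,5-dimethylphenyl in place of 2,6-dimethylphenyl, with the same atoms joined differently, gives a large fall (a number 52.3 percentage points lower from compound 3 to compound 4 (beyond the scatter)), and 2,5-dimethylphenyl in place of 4-bromophenyl gives another (a number 56.4 percentage points lower from compound 2 to compound 4 (beyond the scatter)). With 2,5-dimethylphenyl held fixed, tert-butyl in place of methyl on an aromatic carbon also lowers the read-out (a number 40.1 percentage points lower from compound 1 to compound 4 (beyond the scatter)), so the tert-butyl compounds 2 and 3 do not show what tert-butyl does with every group on that nitrogen. The data offer nothing that explains either fall.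

Still open, from the compounds shown here alone, is whether methyl in place of tert-butyl would change the read-out in the same direction with 2,6-dimethylphenyl or 4-bromophenyl on the nitrogen, as only the 2,5-dimethylphenyl pair allows that comparison. Also open, going by these compounds, is how 2,5-dichlorophenyl or 2-methylphenyl on that nitrogen, or isopropyl in place of tert-butyl, would read out alongside the shared core.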